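Swapping the Alkenyl Group for an Alkynyl One

The source may hold more compounds than are shown below. What is called first, only, known or untested is meant among the compounds shown, and "the series" means these compounds.

Compound 1, `C=C(C)COC[n+]1ccn(C)c1/C=N/O`, gives 7.99 in a physicochemical assay for acid dissociation.
Compound 2, `C=CC(CCC)OC[n+]1ccn(C)c1/C=N/O`, gives 7.99 in this assay.

Compound 1 stands level with compound 2 at the digits shown; the two numbers lie within the usual scatter of repeated measurements, so nothing separates them. Among the compounds with values here, no step between compounds that differ in a single place has been measured, so the size of a step in this assay cannot be read off directly. What the two values do show is that compound 1 and compound 2 carry different groups on the oxygen and still give the same number.

Compound 3, `C#CCC(C)OC[n+]1ccn(C)c1/C=N/O`, has not yet been measured. It differs from compound 1 in one place: 1-methylbut-3-yn-1-yl in place of 2-methylprop-2-en-1-yl on an oxygen on a saturated carbon. The change sits at the same oxygen where compound 1 and compound 2 already differ, and because compound 2 gives 7.99 while compound 1 gives 7.99, a step in this assay of no more than the scatter is expected here as well. The step expected from the estimate, no change at the digits printed from compound 1 to compound 3 (within the scatter), should stay within the scatter. Compound 3 is therefore estimated at 7.99, with a range from 7.7 to 8.3.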

Compound 3, acid dissociation constant: 8.03
Beside the measured number, compound 3's estimate is 0.04 log units below it, and the stated range covers the measured number.
By their numbers in this assay, from the lowest: compounds 1, 2 and 3 (each within the scatter of the next).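

Within the data shown here, putting 1-methylbut-3-yn-1-yl in place of 2-methylprop-2-en-1-yl on an oxygen on a saturated carbon gives, in this assay, a number 0.04 log units higher from compound 1 to compound 3 (within the scatter), and this is the first step read here between two compounds that differ in one place. It shows that, at this position, a group with a triple bond and five carbons can take the place of a group with a double bond and four carbons while the read-out stays within the scatter, so this swap leaves the way the proton is given up without any measurable shift. Compounds 1 and 2 had only shown that two different groups on this oxygen could print the same number, whereas this step ties that sameness to one specific exchange of a double bond for a triple bond, although no measurement shown here offers a reason for the result.

The groups compared on this oxygen in compounds 1 and 3 are both open carbon chains with no ring and no net charge, so they say little about very different groups at this place. Going by these compounds, whether an amine, a carboxylic acid or a phenyl ring on this oxygen would also stay within the scatter remains open.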